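Fluoro added beside the trifluoromethyl on the urea aryl

The compounds below may be only part of what the source reports. "The series", "measured", "known", "first", "only" and "open" are said of these compounds alone.

Two ureas on the shared core have been measured. Compound 1 `O=C(Nc1ccc(Oc2ccc(-c3nccs3)cc2)cc1)Nc1ccc(Cl)c([N+](=O)[O-])c1` gives 6870 nM in a functional assay on MDA-MB-231 cells (Homo sapiens) for inhibition, read by MTT assay and WST assay, with a stated time of 72 h; on this read-out higher numbers stand for weaker inhibition and lower numbers for stronger inhibition. Compound 2 `O=C(Nc1ccc(Oc2ccc(-c3nccs3)cc2)cc1)Nc1cccc(C(F)(F)F)c1` gives 9550 nM in this assay. Among the compounds with values here, the only step between them, a 1.4-fold higher number from compound 1 to compound 2 (0.14 log units; within the scatter), lies within the scatter, so the two numbers cannot be told apart, and compound 2 stands with compound 1 as its sole neighbour.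

Compound 3 `O=C(Nc1ccc(Oc2ccc(-c3nccs3)cc2)cc1)Nc1ccc(F)c(C(F)(F)F)c1` differs from compound 2 by fluoro in place of hydrogen on an aromatic carbon, placed ortho to the trifluoromethyl group and para to a large group on the aromatic carbon of the six-membered carbon ring; read one bond further out, 3-(trifluoromethyl)phenyl becomes 4-fluoro-3-(trifluoromethyl)phenyl.

Within the data shown here, no measured step adds a single fluoro to this ring. Among the measured compounds shown here, the one step on record, a 1.4-fold higher number from compound 1 to compound 2 (0.14 log units; within the scatter), exchanges the whole aryl group and yet stays within the scatter, which gives no ground to expect that a smaller change would move the number beyond it. The step from compound 2 to compound 3 is therefore expected to be a 1.1-fold lower number from compound 2 to compound 3 (0.05 log units; within the scatter), essentially flat. Compound 3 is expected to give 8500 nM in this assay, with a range from 3500 nM to 20000 nM.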

Compound 3, half-maximal inhibitory concentration: 8660 nM
Estimate against measurement, compound 3: 1.0-fold (0.01 log units) below, and the stated range covers the measured number.
By their numbers in this assay, from the lowest: compounds 1, 3 and 2 (each within the scatter of the next).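

Fluoro in place of hydrogen on the aromatic carbon ortho to the trifluoromethyl group gives a 1.1-fold lower number from compound 2 to compound 3 (0.04 log units; within the scatter) in this assay and is the first single-atom substitution read on this ring, with the two numbers indistinguishable. Against the other aryl group, the 4-fluoro-3-(trifluoromethyl)phenyl group gives a 1.3-fold higher number from compound 1 to compound 3 (0.10 log units; within the scatter) and thus adds a third aryl group whose number cannot be told from the others on the shared core, so this position accepts fluoro with no readable difference. Nothing available on these compounds speaks to why these aryl groups read alike.

The aryl groups shown carry only chloro, nitro, fluoro and trifluoromethyl, so it remains open how an amine, a carboxylic acid or a longer chain on this aromatic carbon would read. Also open, on these data alone, is how a change to the shared core itself would read against these numbers, and whether any replacement on the urea aryl can move the number beyond the scatter.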